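The compounds below may be only part of what the source reports. "The series", "measured", "known", "first", "only" and "open" are said of these compounds alone.

Going by the values given here, compound 3 `COc1cc(/C=C/C(=O)NCCn2c(C)cc3ccccc32)cc(OC)c1OCCO` is one of three compounds measured in an assay on C6 cells for antagonist activity at prostaglandin E2 receptor EP2 subtype (Homo sapiens), read by TR-FRET, with stated times of 10 min and 40 min, tested at 1 uM (on this read-out lower numbers stand for stronger inhibition and higher numbers for weaker inhibition), and in this assay compound 3 gives 3.7 nM. Among the compounds with values here, compound 1 `COc1cc(/C=C/C(=O)NCCn2c(C)cc3ccccc32)cc(OC)c1` gives 3.4 nM; the one single-point step measured, a 1.1-fold higher number from compound 1 to compound 3 (0.04 log units; within the scatter), stays within the scatter, so these two numbers cannot be told apart. Compound 2 `COc1cc(/C=C/C(=O)NCc2c(C)n(C)c3ccccc23)cc(OC)c1OC` reaches only the limit of the assay, > 1000 nM, and so gives no number. Compound 4 `COc1cc(/C=C/C(=O)NCCn2c(C(F)(F)F)cc3ccccc32)cc(OC)c1OCCO` differs from compound 3 by trifluoromethyl in place of methyl on an aromatic carbon. Within the data shown here, no measured step concerns a trifluoromethyl in place of a methyl, and the one step measured, an added 2-hydroxyethoxy, says nothing about this change, so its size and direction remain open. Compound 4 is expected, as a guess, to give 10 nM, between 3 nM and 40 nM, a step of a 2.7-fold higher number from compound 3 to compound 4 (0.43 log units; beyond the scatter).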

Compound 4, antagonist equilibrium constant: 58.3 nM
The estimate for compound 4 lay 5.8-fold (0.77 log units) below the measured number, and the stated range ends below it.
By their numbers in this assay, from the lowest: compounds 1 and 3 (each within the scatter of the next); then compound 4. At a limit, above all of these: compound 2.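

The methyl next to the ring nitrogen cannot be changed freely: in this assay, trifluoromethyl in its place gives a 16-fold higher number from compound 3 to compound 4 (1.20 log units; beyond the scatter), a large step, whereas the added 2-hydroxyethoxy gave a 1.1-fold higher number from compound 1 to compound 3 (0.04 log units; within the scatter). Compound 4 still gives a measured number, so this change weakens inhibition without removing it. Nothing shown gives a reason for the size of this step.

On these data alone, whether hydrogen, ethyl or a chlorine atom at this position would match compound 3 stays open. So does whether trifluoromethyl would cost as much on compound 1.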